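The source may hold more compounds than are shown below. What is called first, only, known or untested is meant among the compounds shown, and "the series" means these compounds.

Compound 2 `CC(C)C(c1ccc(-c2ccc3cccc(F)c3c2)[nH]c1=O)N1CCN/C1=N\C#N` gives 0.327 h in an ADME assay on microsomes from liver (Rattus norvegicus) for metabolic stability; a lower number here means that the compound disappears faster, a higher number that the compound lasts longer; compound 1 `CCC(CC)(c1nnc[nH]1)c1ccc(-c2ccc3cc(F)cc(F)c3c2)[nH]c1=O` gives 1.26 h and compound 3 `CC(C)[C@@H](C[C@H]1CCNC1=O)c1ccc(-c2ccc3cccc(F)c3c2)[nH]c1=O` gives 0.507 h. Compound 2 thus has the lowest of the three numbers: its gap to compound 3 is within the scatter, while its gap to compound 1 lies beyond it. Compound 4 `CC(C)C(/C=C1/CCNC1=O)c1ccc(-c2ccc3cccc(F)c3c2)[nH]c1=O` differs from compound 2 by one change: a group of 7 heavy atoms (5 carbon, 1 nitrogen, 1 oxygen; one five-membered non-aromatic ring with 1 hetero atom) in place of a group of 8 heavy atoms (4 carbon, 4 nitrogen; one five-membered non-aromatic ring with 2 hetero atoms), on a saturated chain carbon bound to an aromatic carbon and a saturated chain carbon. Among the measured compounds shown here, no directly comparable step between measured compounds exists here, so the expectation leans on compound 3, whose five-membered ring with one hetero atom gives 0.507 h, a little more than compound 2. The step is expected to be a 1.5-fold higher number from compound 2 to compound 4 (0.18 log units; within the scatter), a modest rise that is not clearly beyond the scatter. Compound 4 is estimated at 0.5 h, ranging from 0.25 h to 1 h.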

Compound 4, half-life: 0.06 h
Estimate against measurement, compound 4: 8.3-fold (0.92 log units) above; measured number outside the range, below it.
By their numbers in this assay, from the lowest: compound 4; then compounds 2 and 3 (each within the scatter of the next); then compound 1.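

In this assay, the group with one five-membered non-aromatic ring with 1 hetero atom and 2 double bonds outside aromatic rings, in place of the group with one five-membered non-aromatic ring with 2 hetero atoms, gives a 5.5-fold lower number from compound 2 to compound 4 (0.74 log units; beyond the scatter) at this position. This shows that a change on this saturated chain carbon can shift the half-life beyond the scatter, here downward. Nothing shown gives a reason for the fall. Which part of the exchanged group carries the step remains open, as does the outcome for an amine or a carboxylic acid on this carbon.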